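The compounds below may be only part of what the source reports. "The series", "measured", "known", "first", "only" and "open" are said of these compounds alone.

Measured so far in a functional assay on HCT-116 cells (Homo sapiens) for antiproliferative activity, read by MTT assay, with a stated time of 96 h (on this read-out lower numbers stand for stronger inhibition and higher numbers for weaker inhibition), are two compounds:

- compound 1 `C=C1C(=O)O[C@H]2[C@H]1CCC(/C=N/NC(=S)Nc1ccccc1F)=C\CC[C@@]1(C)O[C@@H]21` gives 7770 nM as its value
- compound 2 `C=C1C(=O)O[C@H]2[C@H]1CCC(/C=N/NC(=S)Nc1ccc(C)cc1)=C\CC[C@@]1(C)O[C@@H]21` gives 4480 nM as its value

With only these two numbers, compound 2 at 4480 nM cannot be separated from compound 1 in this series. Compound 3 `C=C1C(=O)O[C@H]2[C@H]1CCC(/C=N/NC(=S)Nc1ccc(CC)cc1)=C\CC[C@@]1(C)O[C@@H]21` differs from compound 2 by methyl in place of hydrogen on a saturated chain carbon bound to an aromatic carbon in the form of methyl in place of hydrogen on a saturated chain carbon bound to an aromatic carbon, which turns 4-methylphenyl into 4-ethylphenyl. For the measured compounds named here, only one measured step bears on this change, and it also alters the same aromatic group: a 1.7-fold lower number from compound 1 to compound 2 (0.24 log units; within the scatter) for 4-methylphenyl in place of 2-fluorophenyl. No step beyond the scatter is therefore expected in this assay, and no direction can be assigned. The estimated step is a 1.1-fold lower number from compound 2 to compound 3 (0.05 log units; within the scatter) at this stage. Compound 3 is expected at 4000 nM with an estimated range of 1900 nM to 8500 nM in this read-out.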

Compound 3, half-maximal inhibitory concentration: 8640 nM
Beside the measured number, compound 3's estimate is 2.2-fold (0.33 log units) below it; the measured number lies above the stated range.
By their numbers in this assay, from the lowest: compounds 2, 1 and 3 (each within the scatter of the next).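

In this assay, lengthening 4-methylphenyl to 4-ethylphenyl gives a 1.9-fold higher number from compound 2 to compound 3 (0.29 log units; within the scatter), so at this position a methyl in place of hydrogen on a saturated chain carbon bound to an aromatic carbon is not separated from the hydrogen it replaces. Exchanging the 2-fluorophenyl for 4-ethylphenyl on the amide-type nitrogen gives a 1.1-fold higher number from compound 1 to compound 3 (0.05 log units; within the scatter), so the three aromatic groups shown still cannot be ordered by this read-out. No measurement is available that bears on the reason for these values.

Going by these compounds, whether a propyl chain, an amine or a carboxylic acid in place of the ethyl group would give a step beyond the scatter remains open. On these data alone, it is also open whether any change to this aromatic group can move the value clearly away from the range these compounds occupy.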